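The source may report more compounds than this note shows. Statements on the series, on what has been measured and on what is new or still open speak of the compounds shown alone.

Compound 1 `ClCc1ccc(Cn2cnc3c(Cl)ncnc32)cc1` and compound 3 `ClCc1ccccc1Cn1cnc2c(Cl)ncnc21` are built from the same atoms joined differently; the difference between the two cores is not broken down here. Among the measured compounds shown here, in a functional assay on CCRF-CEM cells (Homo sapiens) for cytotoxicity, read by sulforhodamine B assay, with a stated time of 48 h (on this read-out lower numbers stand for stronger inhibition of growth and higher numbers for weaker inhibition of growth), compound 1 gives 510 nM, while compound 3 gives 1280 nM, the second highest of the three numbers measured so far. Compound 2 `Nc1nc(Cl)c2ncn(Cc3ccc(CCl)cc3)c2n1` is obtained from compound 1 by a single change, (amino in place of hydrogen on an aromatic carbon), and in this assay compound 2 gives 2690 nM. That change alone produced a 5.3-fold higher number from compound 1 to compound 2 (0.72 log units; beyond the scatter). Compound 4 `Nc1nc(Cl)c2ncn(Cc3ccccc3CCl)c2n1` differs from compound 3 by the same change, (amino in place of hydrogen on an aromatic carbon), at a place described in the same words. For the measured compounds named here, the step expected for compound 4 is a 4.7-fold higher number from compound 3 to compound 4 (0.67 log units; beyond the scatter), because a 5.3-fold higher number from compound 1 to compound 2 (0.72 log units; beyond the scatter) is the only example of this change available, though a second core need not repeat the first exactly. Starting from the number of compound 3, 1280 nM, the estimate for compound 4 in this assay is 6000 nM. For compound 4 the expected range runs from 2500 nM to 15000 nM.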

Compound 4, concentration for 50% growth inhibition: 17800 nM
For compound 4 the middle estimate is 3.0-fold (0.47 log units) below the measured one; the whole stated range lies below it.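

In this assay, amino in place of hydrogen on an aromatic carbon again moves the read-out towards weaker inhibition of growth, with a 14-fold higher number from compound 3 to compound 4 (1.14 log units; beyond the scatter), so the direction of the change carries over from the core of compound 1 to the core of compound 3. Set side by side, the two steps cannot be told apart in size: the same change on two cores in this assay, a 5.3-fold higher number (0.72 log units; beyond the scatter) from compound 1 to compound 2 and a 14-fold higher number (1.14 log units; beyond the scatter) from compound 3 to compound 4, 2.6-fold (0.42 log units) apart, within the scatter of two such steps. This rests on two pairs of compounds only, so it supports carrying the change between these two cores but does not show that it would hold on any other core, and it gives no reason for the loss of growth inhibition.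

What the compounds shown leave open is whether a methylamino or a hydroxyl group in place of the amino group would shift the number in the same way. Also open, on these data alone, is whether the step persists when the chloro group on the same ring gives way to a methoxy group, or the chloromethyl group to a hydroxymethyl group.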